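From 3-chlorobenzyl to 2-chlorobenzyl: expectations for compound 4

The source may hold more compounds than are shown below. What is called first, only, known or untested is meant among the compounds shown, and "the series" means these compounds.

In a functional assay on DU-145 cells (Homo sapiens) for cytotoxicity, read by MTT assay, with a stated time of 24 h (on this read-out lower numbers stand for stronger inhibition and higher numbers for weaker inhibition), compound 1 `COc1ccc(/C=C2\CN(C(=S)SCc3cn(Cc4ccc(F)cc4)nn3)C/C(=C\c3ccc(OC)cc3)C2=O)cc1` gives 74600 nM, and compound 2 `Cc1ccc(/C=C2\CN(C(=S)SCc3cn(Cc4ccc(F)cc4)nn3)C/C(=C\c3ccc(C)cc3)C2=O)cc1` gives 38800 nM. Compound 3 `Cc1ccc(/C=C2\CN(C(=S)SCc3cn(Cc4cccc(Cl)c4)nn3)C/C(=C\c3ccc(C)cc3)C2=O)cc1` gives no exact number, only a limit of > 80000 nM. Its place on the scale is therefore (the limit of > 80000 nM in this assay, at which 1 of the 3 values shown sits).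

Compound 4 `Cc1ccc(/C=C2\CN(C(=S)SCc3cn(Cc4ccccc4Cl)nn3)C/C(=C\c3ccc(C)cc3)C2=O)cc1` has the same atoms as compound 3, joined differently: 2-chlorophenyl in place of 3-chlorophenyl on a saturated chain carbon bound to an aromatic nitrogen. It carries 2-chlorophenyl in place of 3-chlorophenyl on a saturated chain carbon bound to an aromatic nitrogen.

Going by the values given here, only one measured step changes this group: an at least 2.0-fold higher number from compound 2 to compound 3 (0.31 log units; beyond the scatter). Among the compounds with values here, it replaces 4-fluorophenyl with 3-chlorophenyl, so it shows that this group can matter, but no measured step goes from one chlorophenyl to another. The limit also hides the true starting number. No step beyond the scatter is therefore expected in this assay, and the reading may again end at a limit.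

The estimated change is a number no higher from compound 3 to compound 4 (the limit leaves the size open). The expected value for compound 4 is 80000 nM, with an estimated range of 40000 nM to 160000 nM.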

Compound 4, half-maximal inhibitory concentration: > 80000 nM
Compound 4: no number, only a limit; the forecaster's own chance of this, stated with the estimate: 50%; the middle value lies on the limit itself.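

In this assay, compound 4 gives no number, only a limit of > 80000 nM. With 2-chlorophenyl in place of 4-fluorophenyl, the shift is an at least 2.0-fold higher number from compound 2 to compound 4 (0.31 log units; beyond the scatter), so a rise on this read-out now appears with two different chlorophenyl groups at this place, not only with 3-chlorophenyl. The step from compound 3 to compound 4 cannot be read, and moving the chlorine from one chlorophenyl arrangement to the other therefore gives no measurable difference here, as both compounds stop at the same limit: the limit of > 80000 nM in this assay, at which 2 of the 4 values shown sit.

As far as these compounds go, how far apart compound 3 and compound 4 truly lie remains open. Also open, from the compounds shown here alone, is how a plain phenyl or a pyridine on that saturated chain carbon would compare with compound 2, which gives 38800 nM.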